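The compounds below may be only part of what the source reports. "The series", "measured", "known", "first", "only" and "open" are said of these compounds alone.

Measured so far in a functional assay on aorta for antagonist activity at Alpha-1D adrenergic receptor (Rattus norvegicus); on this read-out higher numbers stand for weaker binding and lower numbers for tighter binding:
compound 1, `CN(C)C(=O)c1cccnc1NCCCN1CCN(c2ccccc2O)CC1`, gives 63.1 nM
compound 2, `CN(C)C(=O)c1cccnc1NCCCN1CCN(c2ccccc2OCC(C)(C)C)CC1`, gives 50.1 nM
compound 3, `CN(C)C(=O)c1cccnc1NCCCN1CCN(c2ccccc2-c2ccccc2)CC1`, gives 63.1 nM

Compound 1 stands level with compound 3 at the digits shown, the two together the highest of the three numbers; its furthest neighbour is compound 2, and even that gap lies within the scatter. Compound 4 is `COc1ccc(N2CCN(CCCNc3ncccc3C(=O)N(C)C)CC2)c(OC)c1`; relative to compound 1 the change is 2,4-dimethoxyphenyl in place of 2-hydroxyphenyl on an amine nitrogen in a ring. Within the data shown here, the steps that bear on this are a 1.3-fold lower number from compound 1 to compound 2 (0.10 log units; within the scatter) and no change at the digits printed from compound 1 to compound 3 (within the scatter), with a 1.3-fold higher number from compound 2 to compound 3 (0.10 log units; within the scatter) likewise. Each replacement so far on the amine nitrogen in a ring has left the number within the scatter, so for compound 4 no step beyond the scatter is expected in this assay. The estimate for compound 4 is 50 nM, range 20 nM to 160 nM. That estimate corresponds to an expected step of a 1.3-fold lower number from compound 1 to compound 4 (0.10 log units; within the scatter).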

Compound 4, dissociation constant: 1000 nM
Estimate against measurement, compound 4: 20-fold (1.30 log units) below; the measured number lies above the stated range.
By their numbers in this assay, from the lowest: compounds 2, 1 and 3 (each within the scatter of the next); then compound 4.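

Among these compounds, the aryl group on the amine nitrogen in a ring is not indifferent in this assay: 2,4-dimethoxyphenyl in place of 2-hydroxyphenyl gives a 16-fold higher number from compound 1 to compound 4 (1.20 log units; beyond the scatter), the first step here beyond the scatter. The neopentyloxy and phenyl replacements in compound 2 and compound 3 stayed within the scatter of compound 1, so that tolerance does not extend to compound 4. Nothing available accounts for this step.

Open, from the compounds shown here alone, is which methoxy group carries the loss: 2-methoxyphenyl and 4-methoxyphenyl would separate the two.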